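Extending the saturated chain beyond compound 2

The compounds below may be only part of what the source reports. "The series", "measured", "known", "first", "only" and "open" are said of these compounds alone.

Measured in a functional assay, read by spectrophotometry, with a stated time of 6 min (a higher number here means a weaker inhibitor, a lower number a stronger inhibitor), as follows:
Compound 1 `CCCCCCCCCCCCOc1cc(OC)ccc1C(C)=O` gives 40700000 nM
Compound 2 `CCCCCCCCCCCCCCOc1cc(OC)ccc1C(C)=O` gives 38000000 nM

In this assay compound 2 stands at 38000000 nM and lies within the scatter of compound 1. The change ethyl in place of hydrogen on a saturated chain carbon, ten or more bonds along the chain from an oxygen on an aromatic ring leads from compound 2 to compound 3 `CCCCCCCCCCCCCCCCOc1cc(OC)ccc1C(C)=O` and nothing else differs. For the measured compounds named here, the one measured step of this kind is a 1.1-fold lower number from compound 1 to compound 2 (0.03 log units; within the scatter) and it lay within the scatter. No step beyond the scatter is therefore expected in this assay and no direction can be foreseen, though a single step is thin evidence. The estimated step is a 1.0-fold lower number from compound 2 to compound 3 (0.01 log units; within the scatter) and no more than that is expected. Compound 3 is estimated at 37000000 nM with 20000000 nM to 70000000 nM as the expected range.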

Compound 3, half-maximal inhibitory concentration: 36300000 nM
For compound 3 the middle estimate is 1.0-fold (0.01 log units) above the measured one, and the stated range covers the measured number.
By their numbers in this assay, from the lowest: compounds 3, 2 and 1 (each within the scatter of the next).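

In this assay a further ethyl at this place again stays within the scatter (a 1.0-fold lower number from compound 2 to compound 3 (0.02 log units; within the scatter)), and the larger change, butyl in place of hydrogen, does so as well (a 1.1-fold lower number from compound 1 to compound 3 (0.05 log units; within the scatter)). Even this larger change at this place therefore moves the number no further than the scatter across compound 1, compound 2 and compound 3. No measurement is available that would account for this. Going by these compounds, whether a longer chain, or an amine or a carboxylic acid in place of hydrogen at this place, would move the number beyond the scatter stays open.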